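A few compounds are considered here, and "the series" means these few. Any claim that something is new, unique, unknown or untested is made for them only; others in the source may bear on it.

Three compounds have been measured in a functional assay on COR-L23 cells (Homo sapiens) for antiproliferative activity, read by CellTiter-Glo, with a stated time of 4 days; on this read-out lower numbers stand for stronger inhibition and higher numbers for weaker inhibition:

- compound 1 `CC(=O)NCc1ncc2cc(COc3ccc(C(=O)NCc4cccnc4)cc3)n(CCC3CCCCC3)c2n1`: 77 nM
- compound 2 `CCC(=O)NCc1ccc(NC(=O)[C@H]2C[C@@H]2c2cccnc2)cc1`: > 2500 nM (a limit of the assay, not a number)
- compound 3 `C[C@H](NC(=O)C1CCOCC1)c1ccc(NC(=O)[C@H]2C[C@@H]2c2cccnc2)cc1`: 7 nM

Of the two true numbers, compound 3 holds the lower at 7 nM. Compound 1 stands higher at 77 nM, and that gap lies beyond the scatter. Compound 2 gives > 2500 nM, which is a limit.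

The next compound to be tested is compound 4 `C[C@H](NC(=O)c1ncccn1)c1ccc(NC(=O)[C@H]2C[C@@H]2c2cccnc2)cc1`, which differs from compound 3 in one place: pyrimidin-2-yl in place of oxan-4-yl on a carbonyl carbon. Pyrimidin-2-yl stands in place of oxan-4-yl on a carbonyl carbon, so a non-aromatic ring gives way to an aromatic one of the same heavy-atom count. Going by the values given here, no measured pair here shows a change of this kind, so the expectation can only start from compound 3 at 7 nM. A slightly higher number is expected, with a shift that probably stays within the scatter, though the uncertainty is wide in the direction of weaker inhibition. The expected step is a 1.7-fold higher number from compound 3 to compound 4 (0.23 log units; within the scatter). In this assay the estimate for compound 4 is 12 nM, with an expected range from 3 nM to 60 nM.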

Compound 4, half-maximal inhibitory concentration: 17 nM
Compound 4: middle estimate off by 1.4-fold (0.15 log units), on the low side, within the range that was stated.
By their numbers in this assay, from the lowest: compound 3; then compound 4; then compound 1. At a limit, above all of these: compound 2.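

This is the first step shown at the group on the carbonyl carbon, and in this assay it gives a 2.4-fold higher number from compound 3 to compound 4 (0.39 log units; beyond the scatter). The place accepts a six-membered aromatic ring with 2 hetero atoms in place of a six-membered non-aromatic ring with 1 hetero atom, at the same heavy-atom count, and compound 4 still gives 17 nM, although the exchange carries a modest cost. No measured property of either group bears on this step, and the data give no cause for it.

With only one aromatic and one non-aromatic group at this place, the compounds shown leave open whether the step follows the aromatic character of the ring, its hetero atoms, or neither, and a phenyl, pyridin-2-yl or piperidin-4-yl group on the same carbonyl carbon would help to separate these. They also leave open how this place responds to groups other than six-membered rings, such as a cyclopropyl ring or an open chain like isopropyl.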